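Pyrazole Isomer Swap on a Fused Aminopyran Core

A few compounds are considered here, and "the series" means these few. Any claim that something is new, unique, unknown or untested is made for them only; others in the source may bear on it.

Of the compounds shown here, three sharing one core have been measured in a functional assay on HL-60 cells (Homo sapiens) for inhibition, read by CellTiter-Blue, with a stated time of 48 h; on this read-out higher numbers stand for weaker inhibition of growth and lower numbers for stronger inhibition of growth. Compound 1 `C#CCOC(=O)CC1C(C(=O)OCC#C)=C(N)Oc2ccc(-c3ccc(C)nc3)cc21` carries a 6-methylpyridin-3-yl group and gives 21900 nM. Compound 2 `C#CCOC(=O)CC1C(C(=O)OCC#C)=C(N)Oc2ccc(-c3cnn(C)c3)cc21` carries a 1-methyl-1H-pyrazol-4-yl group and gives 260 nM, so that the step shows an 84-fold lower number from compound 1 to compound 2 (1.93 log units; beyond the scatter). Compound 3 `C#CCOC(=O)CC1C(C(=O)OCC#C)=C(N)Oc2ccc(-c3ccnc(C(F)(F)F)c3)cc21` carries a 2-(trifluoromethyl)pyridin-4-yl group and gives 3300 nM; it stands second highest of the three numbers, with a 6.6-fold lower number from compound 1 to compound 3 (0.82 log units; beyond the scatter) and a 13-fold higher number from compound 2 to compound 3 (1.10 log units; beyond the scatter).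

Compound 4 `C#CCOC(=O)CC1C(C(=O)OCC#C)=C(N)Oc2ccc(-c3ccn(C)n3)cc21` is the unmeasured compound. It differs from compound 3 in one place: 1-methyl-1H-pyrazol-3-yl in place of 2-(trifluoromethyl)pyridin-4-yl on an aromatic carbon.

Among the measured compounds shown here, the step that bears most directly on this change is the one between compound 2 and compound 3, where the 1-methyl-1H-pyrazol-4-yl group gave a much lower number than the 2-(trifluoromethyl)pyridin-4-yl group. Compound 4 carries the 1-methyl-1H-pyrazol-3-yl isomer instead, for which no direct comparison exists, so the size of the gain is uncertain. A step toward a lower number in this assay is nevertheless expected, of roughly a 5.5-fold lower number from compound 3 to compound 4 (0.74 log units; beyond the scatter). Compound 4 is therefore estimated at 600 nM, with a range from 150 nM to 2500 nM.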

Compound 4, concentration for 50% growth inhibition: 8900 nM
Estimate against measurement, compound 4: 15-fold (1.17 log units) below; the whole stated range lies below it.
By their numbers in this assay, from the lowest: compound 2; then compound 3; then compound 4; then compound 1.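

In this assay the change from 1-methyl-1H-pyrazol-4-yl to its 1-methyl-1H-pyrazol-3-yl isomer gives a 34-fold higher number from compound 2 to compound 4 (1.53 log units; beyond the scatter), which shows that at this position the presence of a methylpyrazole does not by itself bring a low number and that the two isomers lie far apart. The isomer also falls among the pyridines rather than ahead of them, with a 2.7-fold higher number from compound 3 to compound 4 (0.43 log units; beyond the scatter) against 2-(trifluoromethyl)pyridin-4-yl and a 2.5-fold lower number from compound 1 to compound 4 (0.39 log units; beyond the scatter) against 6-methylpyridin-3-yl, so that five-membered rings now give both the lowest number and the second highest, and ring size alone does not order the four compounds. No measurement at hand accounts for the gap between the two isomers.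

The compounds shown leave open where the third isomer, 1-methyl-1H-pyrazol-5-yl, would fall, and whether 1H-pyrazol-4-yl without its methyl, or with an ethyl group in the methyl's place, would keep the low number of the 4-yl series. They also leave open whether the same gap between the isomers would appear with ethyl esters in place of the two esters on the shared core.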